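The compounds below may be only part of what the source reports. "The series", "measured", "known", "first", "only" and "open" are said of these compounds alone.

Working notes on the series. In a functional assay on SW480 cells (Homo sapiens) for antiproliferative activity, read by MTT assay, with a stated time of 48 h (on this read-out higher numbers stand for weaker inhibition and lower numbers for stronger inhibition), compound 1 `CC(C)=CCC[C@]1(C)/C=C/[C@@H](OC(=O)C=C(C)C)[C@](C)(O)/C=C/C(=O)/C(CCl)=C\C1` gives 390 nM, compound 2 `CC(C)=CCC[C@]1(C)/C=C/[C@@H](OC(=O)C=C(C)C)[C@](C)(O)/C=C/C(=O)/C(CN2CCN(C)CC2)=C\C1` gives 800 nM and compound 3 `CC(C)=CCC[C@]1(C)/C=C/[C@@H](OC(=O)C=C(C)C)[C@](C)(O)/C=C/C(=O)/C(CN=[N+]=[N-])=C\C1` gives 4230 nM. Compound 3 therefore has the highest number of the three, as shown by an 11-fold higher number from compound 1 to compound 3 (1.04 log units; beyond the scatter) and by a 5.3-fold higher number from compound 2 to compound 3 (0.72 log units; beyond the scatter). The remaining measured step is a 2.1-fold higher number from compound 1 to compound 2 (0.31 log units; beyond the scatter).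

The next change leads to compound 4 `CCN(CC)C(=O)/C1=C/C[C@](C)(CCC=C(C)C)/C=C/[C@@H](OC(=O)C=C(C)C)[C@](C)(O)/C=C/C1=O` and is diethylcarbamoyl in place of azidomethyl on a double-bonded ring carbon. In words, this is diethylcarbamoyl in place of azidomethyl on a double-bonded ring carbon. All three measured steps exchange a group on the saturated chain carbon, and none removes that carbon, so they bear on this change only indirectly. Both groups measured against azido gave lower numbers, which leans the expectation slightly downward from compound 3, though the data contain no amide for comparison.

The expected change in this assay is a 1.7-fold lower number from compound 3 to compound 4 (0.23 log units; within the scatter), a small move to a lower number that is not expected to clear the scatter. For compound 4 the estimated value is 2500 nM, with an expected range of 700 nM to 9000 nM.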

Compound 4, half-maximal inhibitory concentration: 11700 nM
Beside the measured number, compound 4's estimate is 4.7-fold (0.67 log units) below it; measured number above the stated range.
By their numbers in this assay, from the lowest: compound 1; then compound 2; then compound 3; then compound 4.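

In this assay, diethylcarbamoyl on the double-bonded ring carbon is the only group shown that removes the saturated chain carbon, and it gives the highest number in the series (a 2.8-fold higher number from compound 3 to compound 4 (0.44 log units; beyond the scatter)). The gap widens against the other two groups (a 15-fold higher number from compound 2 to compound 4 (1.17 log units; beyond the scatter); a 30-fold higher number from compound 1 to compound 4 (1.48 log units; beyond the scatter)), so azidomethyl no longer marks the weak end of the range at this position. No supporting data explain the rise in the number.

The compounds shown do not separate the effect of removing the chain carbon from that of the diethylamide itself. A primary amide or a carboxylic acid on the same ring carbon, and a hydroxymethyl or aminomethyl group that keeps the chain carbon, would help divide these two changes.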